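Swapping the benzylamine linker for an aryl thioether

This account rests on a few compounds, and the source may have more. Where it says the series, first, only, none or still open, it means among the compounds named here.

Compound 2 `Nc1cc(N)c2nc(-c3ccccc3)c(NCc3ccc(F)cc3)nc2c1` gives 19500 nM in a functional assay on MDA-MB-231 cells (Homo sapiens) for inhibition, read by sulforhodamine B assay, with a stated time of 48 h (a lower number here means that less compound is tolerated, a higher number that more compound is tolerated), and that is the only number shown for this series. Compound 1 `Nc1cc(N)c2nc(-c3ccccc3)c(NCc3ccc(Cl)c(Cl)c3)nc2c1` is reported in this assay only as a limit, < 100000 nM. Because of the limit of < 100000 nM in this assay, at which 1 of the 2 values shown sits, the step that the limit leaves unreadable from compound 1 to compound 2 cannot be read in size. Compound 3 `Nc1cc(N)c2nc(-c3ccccc3)c(Sc3ccc(Cl)c(Cl)c3)nc2c1` differs from compound 2 by (3,4-dichlorophenyl)sulfanyl in place of (4-fluorobenzyl)amino on an aromatic carbon. For the measured compounds named here, the one measured step bears on it only in part, as it exchanged the aryl group while keeping the benzylamine linker, and its size stays hidden behind the limit of compound 1. No readable step therefore speaks for a shift in either direction, and for compound 3 the expectation in this assay is a step of a 1.0-fold higher number from compound 2 to compound 3 (0.01 log units; within the scatter) that stays within the usual scatter. The estimated value for compound 3 is 20000 nM, with a range from 5000 nM to 80000 nM.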

Compound 3, concentration lethal to 50% of the cells: < 100000 nM
Compound 3 gave a limit, no number; the forecaster's own chance of this, stated with the estimate: 15%; the middle value does not contradict the limit.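

Compound 3 is reported in this assay only as a limit, < 100000 nM. No new step can therefore be read between compound 2 and compound 3: the limit of < 100000 nM in this assay, at which 2 of the 3 values shown sit.

The compounds shown leave open how the (3,4-dichlorophenyl)sulfanyl group of compound 3 compares in size of effect with the (4-fluorobenzyl)amino group of compound 2.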